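Swapping Methoxy for Bromo on the Pendant Phenyl Ring

The source may hold more compounds than are shown below. What is called first, only, known or untested is meant among the compounds shown, and "the series" means these compounds.

Compound 2 `COc1ccc(-c2cn3ccnc3c(-c3ccc4ncn(C5CCCCC5)c4c3)n2)cc1` stands highest of the three compounds measured in a functional assay on DU-145 cells (Homo sapiens) for inhibition, read by sulforhodamine B assay, with a stated time of 48 h, tested at 10 uM (a higher number here means more inhibition at the concentration tested (going by the name of the read-out), a lower number less inhibition), where compound 2 gives 81.8%. Compound 1 `c1ccc(-c2cn3ccnc3c(-c3ccc4ncn(C5CCCCC5)c4c3)n2)cc1` gives 29.3% in this assay, and compound 3 `Fc1ccc(-c2cn3ccnc3c(-c3ccc4ncn(C5CCCCC5)c4c3)n2)cc1` gives 1.17%. All three steps lie beyond the scatter: a number 52.5 percentage points higher from compound 1 to compound 2 (beyond the scatter), a number 28.1 percentage points lower from compound 1 to compound 3 (beyond the scatter) and a number 80.6 percentage points lower from compound 2 to compound 3 (beyond the scatter). Compound 4 `Brc1ccc(-c2cn3ccnc3c(-c3ccc4ncn(C5CCCCC5)c4c3)n2)cc1` differs from compound 2 by bromo in place of methoxy on an aromatic carbon. Within the data shown here, the steps that bear on it are a number 80.6 percentage points lower from compound 2 to compound 3 (beyond the scatter) and a number 28.1 percentage points lower from compound 1 to compound 3 (beyond the scatter), both downward, the first of them large. A drop beyond the scatter is therefore expected in this assay, although bromo is not fluoro and the size remains uncertain. Compound 4 is estimated at 18%, within 0% to 50%, an expected step of a number 63.8 percentage points lower from compound 2 to compound 4 (beyond the scatter).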

Compound 4, a percentage reported as inhibition, at one concentration (the size of the read-out at that concentration, not a potency): 5.66%
Compound 4: the middle estimate sits 12.3 percentage points above what was measured; measured number inside the range.
By their numbers in this assay, from the lowest: compounds 3 and 4 (each within the scatter of the next); then compound 1; then compound 2.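

In this assay, bromo at this place, para to a large group, gives up most of what methoxy gave (with a number 76.1 percentage points lower from compound 2 to compound 4 (beyond the scatter)) and also falls short of the unsubstituted compound 1 (with a number 23.6 percentage points lower from compound 1 to compound 4 (beyond the scatter)). The two halogens are not told apart (with a number 4.5 percentage points higher from compound 3 to compound 4 (within the scatter)), so of the four compounds only the 4-methoxyphenyl one, compound 2, stands above compound 1. Nothing measured here accounts for this difference between methoxy and the halogens. Still open, going by these compounds, is whether a longer chain such as ethoxy, an amine or a carboxylic acid at this place would match compound 2 or fall with the halogens.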